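A Hydrazide in Place of an Ester on a Nitro Core

The source may report more compounds than this note shows. Statements on the series, on what has been measured and on what is new or still open speak of the compounds shown alone.

Compound 1 `CCOC(=O)CSCc1nc2cc([N+](=O)[O-])ccc2[nH]1` is the starting point. In a functional assay on MCF7 cells (Homo sapiens) for cytotoxicity, read by MTT assay, with a stated time of 48 h (a lower number here means a stronger inhibitor, a higher number a weaker inhibitor), compound 1 gives > 100000 nM, which is a limit of the assay rather than a measured number. Going by the values given here, of the two values so far, one sits at that limit (the limit of > 100000 nM in this assay, at which 1 of the 2 values shown sits). Among the compounds with values here, the only other measured compound is compound 2 `N#Cc1sc(Nc2ccccc2)nc1NC(=O)CSCc1nc2cc([N+](=O)[O-])ccc2[nH]1`, which in this assay gives 11300 nM; it differs from compound 1 in more than one place, so its value sets no step. Compound 3 `NNC(=O)CSCc1nc2cc([N+](=O)[O-])ccc2[nH]1` carries a small change at the end of the chain: aminoamino in place of ethoxy on a carbonyl carbon. Within the data shown here, no measured step of this kind exists here. With compound 1 sitting at the limit, the step from compound 1 to compound 3 is expected to stay within the scatter, that is an at least 1.1-fold lower number from compound 1 to compound 3 (0.04 log units; that floor lies within the scatter). In this assay compound 3 is therefore estimated at 90000 nM, within a range from 25000 nM to 300000 nM.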

Compound 3, half-maximal inhibitory concentration: 13200 nM
Compound 3: the middle estimate sits 6.8-fold (0.83 log units) above what was measured; measured number outside the range, below it.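

On this carbonyl carbon, the end of the chain clearly matters: with aminoamino in place of ethoxy, this assay shows an at least 7.5-fold lower number from compound 1 to compound 3 (0.87 log units; beyond the scatter). Going by these compounds alone, compound 1 gives > 100000 nM, which is a limit, so this step is only a floor and the real difference could be larger: the limit of > 100000 nM in this assay, at which 1 of the 3 values shown sits. The earlier compounds offered no comparison that differed in one place, so this is the first direct reading of how this position responds to a change.

On these data alone, what remains open is whether the step depends on the aminoamino group itself or would also appear with other groups on the same carbonyl carbon, such as a plain amine or a hydroxyl that makes a carboxylic acid. A longer chain between the sulfur and this carbonyl carbon is also untested by the compounds shown.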